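Acetyl in Place of the Oxime on a Glioblastoma Cell Assay

The source may hold more compounds than are shown below. What is called first, only, known or untested is meant among the compounds shown, and "the series" means these compounds.

Measured so far:
compound 1, `C/C(=N\O)c1ccc(NC(=O)Cn2nc(-c3ccc(Cl)cc3)nc2N)cc1`: 9.67%
compound 2, `C/C(=N/O)c1ccc(NC(=O)Cn2nc(-c3ccccc3)nc2N)cc1`: 8.76%

Of the compounds shown here, two share a core and have been tested in a functional assay on U-251 cells (Homo sapiens) for inhibition, read by sulforhodamine B assay, with a stated time of 48 h, tested at 10 uM; a lower number here means less inhibition of growth, a higher number more inhibition of growth at the concentration tested. Compound 1 gives 9.67%. Compound 2 gives 8.76%. Compound 1 holds the higher of the two numbers, but its nearest neighbour, compound 2, lies only slightly lower, a gap within the scatter of this assay, so the two compounds cannot be told apart on these numbers. Both show weak inhibition of growth at the concentration tested.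

Compound 3, `CC(=O)c1ccc(NC(=O)Cn2nc(-c3ccc(Cl)cc3)nc2N)cc1`, has not yet been tested in this assay. Relative to compound 1 it carries one change: a group of 3 heavy atoms (2 carbon, 1 oxygen; no ring) in place of a group of 4 heavy atoms (2 carbon, 1 nitrogen, 1 oxygen; no ring), on an aromatic carbon

For the measured compounds named here, no measured pair shows what such a change does here. With both measured compounds sitting at low inhibition, the expected step of a number 0.3 percentage points higher from compound 1 to compound 3 (within the scatter) is none beyond the scatter, in no particular direction. For compound 3 in this assay the estimate is 10%, with a range from 0% to 25%.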

Compound 3, percent growth inhibition at one concentration: 5.94%
Compound 3: middle estimate off by 4.1 percentage points, on the high side, and the stated range covers the measured number.
By their numbers in this assay, from the lowest: compounds 3, 2 and 1 (each within the scatter of the next).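

In this assay, for the compounds shown here, putting acetyl in place of the oxime group, on an aromatic carbon para to a large group, gives a number 3.7 percentage points lower from compound 1 to compound 3 (within the scatter), the first direct reading of a change at this position. The exchange takes this group from 1 hydrogen-bond donor to 0 and from 2 hydrogen-bond acceptors to 1, yet the number stays within the usual scatter, and compound 3 remains at weak inhibition of growth, as compound 1 does. This shows that, at the one concentration tested, the oxime group can be swapped for acetyl without a change that can be told apart from noise, though no measurement on hand offers an explanation for the small step.

Still open, from the compounds shown here alone, is whether a different group at this position, such as an amine, a carboxylic acid or a longer alkyl chain, would move growth inhibition clear of the scatter. Also open, going by these compounds, is whether acetyl would give a similar result on the core of compound 2, which has no chlorine on its outer benzene ring.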